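Removing a Methoxy Group from a Weakly Active Amide

The source may report more compounds than this note shows. Statements on the series, on what has been measured and on what is new or still open speak of the compounds shown alone.

Compound 1, `COc1ccc2c(=O)c(/C=C/C(=O)Nc3cccc(Cl)c3)coc2c1`: 470 nM
Compound 2, `COc1ccc(CNC(=O)/C=C/c2coc3cc(O)ccc3c2=O)cc1`: > 100000 nM

In a functional assay on A549 cells (Homo sapiens) for inhibition, read by MTT assay, with a stated time of 48 h (on this read-out higher numbers stand for weaker inhibition and lower numbers for stronger inhibition), compound 1 gives 470 nM. Compound 2 gives only a limit of the assay, > 100000 nM, and so it stands at the limit of > 100000 nM in this assay, at which 1 of the 2 values shown sits. Compound 3, `O=C(/C=C/c1coc2cc(O)ccc2c1=O)NCc1ccccc1`, is not yet measured; it differs from compound 2 by hydrogen in place of methoxy on an aromatic carbon, a hydrogen in place of methoxy on an aromatic carbon. Among the compounds with values here, no measured step shows the size of such a change here. The step that the limit leaves unreadable from compound 2 to compound 3 is expected to stay within the scatter, with compound 3 most likely reported again only as a limit. Compound 3 is estimated at 150000 nM, between 30000 nM and 500000 nM.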

Compound 3, half-maximal inhibitory concentration: > 100000 nM
Compound 3: no number, only a limit; the forecaster's own chance of this, stated with the estimate: 70%; the middle value does not contradict the limit.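

Compound 3 gives only a limit, > 100000 nM. Within the data shown here, compound 2 also gives only a limit, so no step from compound 2 to compound 3 can be read. As far as these compounds go, whether swapping methoxy for hydrogen changes inhibition at all stays open.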